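This account rests on a few compounds, and the source may have more. Where it says the series, first, only, none or still open, it means among the compounds named here.

Working notes on a small series built on one shared core, read in a functional assay on MCF-10A cells (Homo sapiens) for antiproliferative activity, with a stated time of 48 h; on this read-out lower numbers stand for an effect already at smaller amounts and higher numbers for an effect only at larger amounts of compound. Compound 1 `COc1ccc2nc(C)cc(NCc3ccncc3)c2c1` gives 40900 nM, compound 2 `COc1ccc2nc(C)cc(NCc3cccc(F)c3)c2c1` gives 11300 nM, and compound 3 `COc1ccc2nc(C)cc(NCc3cccc(OC(F)F)c3)c2c1` gives 10300 nM. Compound 3 lies within the scatter of compound 2, and the number of compound 1 is higher than both.

The next structure is compound 4 `COc1ccc2nc(C)cc(NCc3cccc(C#N)c3)c2c1`, with cyano in place of difluoromethoxy on an aromatic carbon, meta to a large group (cyano in place of difluoromethoxy on an aromatic carbon).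

Among the measured compounds shown here, two measured steps bear on this. The closest is a 1.1-fold lower number from compound 2 to compound 3 (0.04 log units; within the scatter), a swap of one group for another on the same aromatic carbon, and it stays within the scatter. The other is a 3.6-fold lower number from compound 1 to compound 2 (0.56 log units; beyond the scatter), which is modest but exchanges the whole aromatic ring, so it says less about this change. No step beyond the scatter is therefore expected in this assay, and no direction can be firmly assigned.

The expected change is a 1.4-fold higher number from compound 3 to compound 4 (0.13 log units; within the scatter). For compound 4 the estimated value is 14000 nM, with an expected range of 6500 nM to 30000 nM.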

Compound 4, half-maximal effective concentration: 13400 nM
For compound 4 the middle estimate is 1.0-fold (0.02 log units) above the measured one, within the range that was stated.
By their numbers in this assay, from the lowest: compounds 3, 2 and 4 (each within the scatter of the next); then compound 1.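

At this aromatic carbon, a 1.3-fold higher number from compound 3 to compound 4 (0.11 log units; within the scatter) and a 1.2-fold higher number from compound 2 to compound 4 (0.07 log units; within the scatter) both stay within the scatter in this assay and so give no order among the three groups. Fluoro, difluoromethoxy and cyano now make a set of three on this carbon with no separable difference, which the single earlier step between fluoro and difluoromethoxy could not show. The change from 4 heavy atoms to 2 also leaves no readable mark on the number, and no measured evidence is available to account for this flat response.

Going by these compounds, whether any group on this carbon can move the number beyond the scatter remains open, and an amine, a carboxylic acid or a longer chain here would test that. Also open, on these data alone, is whether the same flat response holds on the other carbons of this aromatic ring.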